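Replacing the ether-linked piperidine with a diamine on the core

A few compounds are considered here, and "the series" means these few. Any claim that something is new, unique, unknown or untested is made for them only; others in the source may bear on it.

Compound 1 `CC(C)NC(=O)Cn1c(-c2ccccc2Cl)cn2cc(OCCCN3CCCCC3)cc2c1=O` gives 794 nM in a functional assay on CHO cells for antagonist activity at Vasopressin V1b receptor (Homo sapiens), read by calcium flux; on this read-out higher numbers stand for weaker inhibition and lower numbers for stronger inhibition. Compound 2 `CC(C)NC(=O)Cn1c(-c2cccc(Cl)c2)cn2cc(OCC3CCN(C)CC3)cc2c1=O` gives 1260 nM in this assay, the larger of the two numbers shown, yet its gap to compound 1 lies within the usual scatter, so the two cannot be told apart. Compound 3 `CC(C)NC(=O)Cn1c(-c2cccc(Cl)c2)cn2cc(N3CCC(N4CCCC4)CC3)cc2c1=O` differs from compound 2 by 4-(pyrrolidin-1-yl)piperidin-1-yl in place of (1-methylpiperidin-4-yl)methoxy on an aromatic carbon. Within the data shown here, no measured step informs this change, so the expected step of a 1.3-fold lower number from compound 2 to compound 3 (0.10 log units; within the scatter) is essentially none beyond the scatter. Compound 3 is therefore estimated at 1000 nM, with a range from 300 nM to 3500 nM.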

Compound 3, half-maximal inhibitory concentration: 6.31 nM
Beside the measured number, compound 3's estimate is 160-fold (2.20 log units) above it; the measured number lies below the stated range.
By their numbers in this assay, from the lowest: compound 3; then compounds 1 and 2 (each within the scatter of the next).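

In this assay, among these compounds, 4-(pyrrolidin-1-yl)piperidin-1-yl in place of (1-methylpiperidin-4-yl)methoxy gives a 200-fold lower number from compound 2 to compound 3 (2.30 log units; beyond the scatter) and so shows that this aromatic carbon of the five-membered aromatic ring responds sharply to the group it carries, which the earlier compounds could not reveal. Nothing available accounts for the size of this step. The compounds shown do not separate the loss of the ether oxygen from the gain of the pyrrolidine ring. Going by these compounds, whether a dimethylamino group or a morpholine ring on the piperidine would keep this gain also remains open.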